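The source may hold more compounds than are shown below. What is called first, only, known or untested is meant among the compounds shown, and "the series" means these compounds.

Of the compounds shown here, three have been tested in an assay on CHO cells for displacement of a labelled ligand from adenosine receptor A1 (Homo sapiens), read by scintillation counting, with a stated time of 120 min, tested at 1 uM; on this read-out higher numbers stand for more inhibition at the one concentration tested (going by the name of the read-out) and lower numbers for less inhibition. Compound 1 `COc1ccc(-n2cc3nc(C)nc(N)c3n2)cc1` gives 30%, compound 2 `O=C(c1ccco1)N(C(=O)c1ccco1)c1nc(-c2ccccc2)nc2cn(-c3ccccc3)nc12` gives 3%, and compound 3 `CC(=O)Nc1nc(C)nc2cn(-c3ccccc3)nc12` gives 25%. Compound 3 stands second highest of the three numbers; its nearest neighbour is compound 1, a number within the scatter of it, while compound 2 lies furthest away, a number beyond the scatter below it.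

Compound 4 `Cc1nc(NC(=O)c2ccncc2)c2nn(-c3ccccc3)cc2n1` has not yet been measured. It differs from compound 3 in one place: pyridin-4-yl in place of methyl on a carbonyl carbon. Among the measured compounds shown here, no step between measured compounds matches this change, so the expected size rests on the structural change alone; a small lowering, not clearly beyond the scatter, is expected, written as a number 5 percentage points lower from compound 3 to compound 4 (within the scatter). Compound 4 is therefore estimated to give 20%, between 5% and 40%.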

Compound 4, a percentage reported as inhibition, at one concentration (the size of the read-out at that concentration, not a potency): 12%
Compound 4: the middle estimate sits 8 percentage points above what was measured; low and high end bracket the measured number.
By their numbers in this assay, from the lowest: compounds 2 and 4 (each within the scatter of the next); then compounds 3 and 1 (each within the scatter of the next).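

Among the compounds shown here, putting pyridin-4-yl in place of methyl on a carbonyl carbon gives, in this assay, a number 13 percentage points lower from compound 3 to compound 4 (beyond the scatter) and offers the first direct comparison at this position. It shows that the group held on this carbonyl carbon can change the read-out, although this rests on a single pair of compounds. Nothing available explains the size or direction of this step. On these data alone, whether an amine or a longer chain at this place would give a number closer to that of compound 3 remains open, as does whether other ring groups would follow pyridin-4-yl.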